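The compounds below may be only part of what the source reports. "The series", "measured", "known", "first", "only" and "open" are said of these compounds alone.

The measured compounds are: compound 1, `C/C(=N\NC(=O)COc1cccc2ccccc12)c1cccc([N+](=O)[O-])c1`, which in a physicochemical assay for lipophilicity, measured as octanol-water partition (a lower number here means a more polar compound, a higher number a more lipophilic compound), gives 3.37; compound 2, `C/C(=N\NC(=O)COc1cccc2ccccc12)c1ccc(C#N)cc1Br`, which in this assay gives 3.61; and compound 3, `C/C(=N\NC(=O)COc1cccc2ccccc12)c1ccccc1`, which in this assay gives 3.65.

Compound 3 holds the highest of the three numbers, but its separation from the others is slight: the step of a number 0.04 log units higher from compound 2 to compound 3 (within the scatter) and the step of a number 0.28 log units higher from compound 1 to compound 3 (within the scatter) are both within the scatter, so no order among the three compounds can be read from these numbers.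

Compound 4, `C/C(=N\NC(=O)COc1cccc2ccccc12)c1ccc([N+](=O)[O-])cc1`, differs from compound 3 by nitro in place of hydrogen on an aromatic carbon. The measured step that bears most directly on this change is a number 0.28 log units higher from compound 1 to compound 3 (within the scatter), where a nitro group was removed from the same aryl ring of the shared core; that removal shifted the number only within the scatter. The other two steps, a number 0.24 log units higher from compound 1 to compound 2 (within the scatter) and a number 0.04 log units higher from compound 2 to compound 3 (within the scatter), were likewise within the scatter. Taking the reverse of the nitro removal as the guide, compound 4 is expected to sit a little lower than compound 3, with an estimated step of a number 0.25 log units lower from compound 3 to compound 4 (within the scatter), not beyond the scatter. The estimate for compound 4 in this assay is therefore 3.4, with a range from 3.1 to 3.7.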

Compound 4, partition coefficient: 3.37
Beside the measured number, compound 4's estimate is 0.03 log units above it; the measured number falls inside the stated range.
By their numbers in this assay, from the lowest: compounds 1, 4, 2 and 3 (each within the scatter of the next).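

Phenyl to 4-nitrophenyl, with the nitro group on an aromatic carbon para to a large group, gives a number 0.28 log units lower from compound 3 to compound 4 (within the scatter) in this assay, the first direct reading of this change at this place on the shared core. Placing the nitro group elsewhere on the ring, as 3-nitrophenyl rather than 4-nitrophenyl, gives no change at the digits printed from compound 1 to compound 4 (within the scatter) and so does not separate the two placements, while the more heavily substituted 2-bromo-4-cyanophenyl, replaced by 4-nitrophenyl, gives a number 0.24 log units lower from compound 2 to compound 4 (within the scatter) and is not separated from it either. No measurement offered here explains why these numbers lie so close together.

As far as these compounds go, all steps among the four compounds lie within the scatter, so it remains open whether an amine, a carboxylic acid or a longer alkyl chain on this aromatic ring would give a step beyond it. From the compounds shown here alone, the acylhydrazone linker and the group at the other end of the shared core are the same in all four compounds, so what a change in either would do to the partition number also stays open.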